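One carboxyphenyl group exchanged for another

The source may report more compounds than this note shows. Statements on the series, on what has been measured and on what is new or still open speak of the compounds shown alone.

In an ADME assay on the whole organism for pharmacokinetics, with Rattus norvegicus as the target, at a dose of 20 mg/kg by the oral route (on this read-out higher numbers stand for higher oral bioavailability and lower numbers for lower oral bioavailability), compound 2 `Cc1c(OCCCCOc2ccc(C(=O)O)cc2)ccc(C(=O)CC(C)C)c1O` gives 23.5% and stands lowest of the three measured compounds. Compound 1 `COc1cc(C(=O)O)ccc1OCCCCOc1ccc(C(=O)CC(C)C)c(O)c1C` reaches 41.9% and compound 3 `COc1ccc(C(=O)O)cc1OCCCCOc1ccc(C(=O)CC(C)C)c(O)c1C` reaches 60.4% on the same read-out. The unmeasured compound 4 `Cc1c(OCCCCOc2ccc(F)c(C(=O)O)c2)ccc(C(=O)CC(C)C)c1O` departs from compound 2 by 3-carboxy-4-fluorophenyl in place of 4-carboxyphenyl on an oxygen on a saturated carbon and so carries 3-carboxy-4-fluorophenyl in place of 4-carboxyphenyl on an oxygen on a saturated carbon. For the measured compounds named here, one measured step bears on this part of the structure, namely a number 18.4 percentage points lower from compound 1 to compound 2 (beyond the scatter) when hydrogen replaces methoxy on an aromatic carbon. Compound 1 and compound 3 both carry methoxy and both lie above compound 2, and neither goes against that small pattern. Going by the values given here, no measured compound carries fluorine, so this is only a loose guide. A modest rise is therefore expected in this assay with a number 11.5 percentage points higher from compound 2 to compound 4 (beyond the scatter) as the estimated step. For compound 4 the estimated value is 35% with an expected range from 17% to 55% in this assay once it is measured.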

Compound 4, oral bioavailability: 58.2%
Compound 4: middle estimate off by 23.2 percentage points, on the low side, and the stated range ends below it.
By their numbers in this assay, from the lowest: compound 2; then compound 1; then compounds 4 and 3 (each within the scatter of the next).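

In this assay the exchange of 4-carboxyphenyl for 3-carboxy-4-fluorophenyl gives a number 34.7 percentage points higher from compound 2 to compound 4 (beyond the scatter) and is the first step shown that changes the group on this oxygen without involving methoxy. Compound 4 carries no methoxy, so among these compounds a number well above that of compound 2 does not depend on that group. No measurement of any property of these compounds is at hand to account for the rise.

The single step changes both the place of the carboxy group and the presence of fluorine, so the compounds shown leave open how much of the rise belongs to each. They also leave open how 3-carboxyphenyl without fluorine would read, and whether chlorine or a nitrile could stand in for the fluorine.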